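Amino in place of chloro: compound 2 to compound 4

A few compounds are considered here, and "the series" means these few. Any claim that something is new, unique, unknown or untested is made for them only; others in the source may bear on it.

Of the compounds shown here, three have been tested in a functional assay on OVCAR-8 cells (Homo sapiens) for cytotoxicity, read by sulforhodamine B assay, with a stated time of 48 h; on this read-out lower numbers stand for higher toxicity in this test and higher numbers for lower toxicity in this test. Compound 1 `ClCc1ccc(Cn2cnc3c(Cl)ncnc32)cc1` gives 64600 nM, compound 2 `ClCc1cccc(Cn2cnc3c(Cl)nc(Cl)nc32)c1` gives 67600 nM, and compound 3 `ClCc1ccccc1Cn1cnc2ncnc(Cl)c21` gives 58900 nM. Compound 2 carries the numerically highest of the three values, but its gaps to compound 1 and to compound 3 both fall within the usual scatter of this measurement, so the three compounds cannot be told apart on these numbers; they form one flat group.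

Compound 4 `Nc1nc(Cl)c2ncn(Cc3cccc(CCl)c3)c2n1` has not yet been measured in this assay. It differs from compound 2 in a single place: amino in place of chloro on an aromatic carbon. Within the data shown here, no pair of measured compounds differs in exactly one place, so there is no measured step to lean on. Given that every measured value sits in the same narrow band, the step is expected to be small, in no clear direction, and the estimated step of a 1.1-fold lower number from compound 2 to compound 4 (0.05 log units; within the scatter) is expected to stay within the scatter. Compound 4 is therefore estimated at 60000 nM, with a range from 25000 nM to 140000 nM.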

Compound 4, concentration lethal to 50% of the cells: 53700 nM
Compound 4: middle estimate off by 1.1-fold (0.05 log units), on the high side; the measured number falls inside the stated range.
By their numbers in this assay, from the lowest: compounds 4, 3, 1 and 2 (each within the scatter of the next).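

Among these compounds, compound 4 provides the first step in this set that changes only one place: on the aromatic carbon between two ring nitrogen atoms, amino stands in place of chloro, and this assay shows a 1.3-fold lower number from compound 2 to compound 4 (0.10 log units; within the scatter). At this position, then, exchanging chloro for amino adds a hydrogen-bond donor and a hydrogen-bond acceptor, yet the read-out cannot be told apart from that of compound 2. No measurement shown here offers an explanation for this result.

Going by these compounds, whether other groups at this position would also leave the read-out unresolved remains open, for example a methoxy group, a dimethylamino group or a thiol. This single step also cannot show whether the same exchange would give a similar result elsewhere on the shared core.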